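The source may report more compounds than this note shows. Statements on the series, on what has been measured and on what is new or still open speak of the compounds shown alone.

Compound 1 `NS(=O)(=O)c1cccc(Nc2nccc(-c3cccnc3)n2)c1`: 200 nM
Compound 2 `NS(=O)(=O)c1cccc(Nc2nccc(-c3ccccn3)n2)c1`: 500 nM
Compound 3 `NS(=O)(=O)c1cccc(Nc2nccc(-c3ccncc3)n2)c1`: 500 nM

Of the compounds shown here, three sharing one core have been tested in a functional assay for inhibition, with Homo sapiens as the target; on this read-out lower numbers stand for stronger inhibition and higher numbers for weaker inhibition. Compound 1 stands at the low end: it gives 200 nM, and both other compounds sit beyond the scatter above it, so it is the strongest inhibitor of the three. The step of a 2.5-fold higher number from compound 1 to compound 2 (0.40 log units; beyond the scatter) comes with pyridin-2-yl in place of pyridin-3-yl, and the step of a 2.5-fold higher number from compound 1 to compound 3 (0.40 log units; beyond the scatter) with pyridin-4-yl in place of pyridin-3-yl; both are modest. Between compound 2 and compound 3 the step of no change at the digits printed from compound 2 to compound 3 (within the scatter), so the two cannot be ordered.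

Compound 4 `c1cc(Nc2nccc(-c3cccnc3)n2)cc(OCCn2ccnc2)c1` differs from compound 1 elsewhere: 2-(1H-imidazol-1-yl)ethoxy in place of sulfamoyl on an aromatic carbon. Among the measured compounds shown here, none of the measured steps touches this part of the molecule; all three concern only the pyridyl group, and they show that this core tolerates small changes with modest shifts. For the measured compounds named here, the change to compound 4 is larger, and no measured pair speaks to it, so the expectation rests on the range seen so far rather than on a directly comparable step. The author expects compound 4 to sit somewhat above compound 1 in this assay, a step of a 2.5-fold higher number from compound 1 to compound 4 (0.40 log units; beyond the scatter), with wide uncertainty. The estimate for compound 4 is 500 nM, within 100 nM to 3000 nM.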

Compound 4, half-maximal inhibitory concentration: 100 nM
For compound 4 the middle estimate is 5.0-fold (0.70 log units) above the measured one; the measured number falls inside the stated range.
By their numbers in this assay, from the lowest: compounds 4 and 1 (each within the scatter of the next); then compounds 2 and 3 (each within the scatter of the next).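

In this assay, the position held by sulfamoyl in compound 1 accepts a much larger group than the pyridyl steps could have suggested: 2-(1H-imidazol-1-yl)ethoxy in place of sulfamoyl gives a 2.0-fold lower number from compound 1 to compound 4 (0.30 log units; within the scatter) and so the two compounds cannot be ordered. The exchange replaces a group with no ring and 1 hydrogen-bond donor by one with a five-membered aromatic ring and 0 hydrogen-bond donors, so with this core and the pyridin-3-yl group, neither the sulfamoyl group nor its donor is needed to keep the read-out at this level. Nothing measured here accounts for the match between such different groups.

The compounds shown leave open whether the imidazole ring or the ethoxy chain matters more at this position, and whether a longer chain, a simple amine or a carboxylic acid on the same carbon would hold the read-out. They also leave open whether the steps among pyridin-3-yl, pyridin-2-yl and pyridin-4-yl carry over when 2-(1H-imidazol-1-yl)ethoxy stands in place of sulfamoyl.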